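The source may hold more compounds than are shown below. What is called first, only, known or untested is meant among the compounds shown, and "the series" means these compounds.

Working notes on the series

The shared core is seen in compound 1 `CN1CCN(CCCCCn2c3c(c4ccccc42)C(=O)c2c[n+]([O-])c4ccccc4c2C3=O)CC1`, which in a functional assay on A-375 cells (Homo sapiens) for cytotoxicity, read by MTT assay, with a stated time of 72 h (a lower number here means a stronger inhibitor, a higher number a weaker inhibitor), gives 1710 nM. Compound 2 `CC1(C)O[C@@H](CO)[C@H](Cn2cc(Cn3c4c(c5ccccc53)C(=O)c3c[n+]([O-])c5ccccc5c3C4=O)nn2)O1` gives 190 nM, and compound 3 `CC1(C)OCC(Cn2cc(Cn3c4c(c5ccccc53)C(=O)c3c[n+]([O-])c5ccccc5c3C4=O)nn2)O1` gives 330 nM. Among the three numbers compound 3 stands second highest; its nearest neighbour is compound 2, and the step of a 1.7-fold higher number from compound 2 to compound 3 (0.24 log units; within the scatter) lies within the scatter, while compound 1 sits further off with a higher number that is beyond the scatter.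

Compound 4 `O=C1c2c[n+]([O-])c3ccccc3c2C(=O)c2c1c1ccccc1n2Cc1cn([C@H]2O[C@H](CO)[C@@H](O)[C@H]2O)nn1` has not yet been measured. It differs from compound 3 by 3,4-dihydroxy-5-(hydroxymethyl)oxolan-2-yl in place of (2,2-dimethyl-1,3-dioxolan-4-yl)methyl on an aromatic nitrogen. Going by the values given here, the only measured step touching this part of the molecule is a 1.7-fold higher number from compound 2 to compound 3 (0.24 log units; within the scatter), which exchanged the 5-(hydroxymethyl)-2,2-dimethyl-1,3-dioxolan-4-yl for the 2,2-dimethyl-1,3-dioxolan-4-yl and moved the number within the scatter only. Among the compounds with values here, no measured pair shows the exchange of the whole (2,2-dimethyl-1,3-dioxolan-4-yl)methyl for the 3,4-dihydroxy-5-(hydroxymethyl)oxolan-2-yl, so the size of that step cannot be read from the data. The expectation is a small step, probably none beyond the scatter, with a slight lean toward a higher number. Compound 4 is therefore estimated at 400 nM, with a range of 150 nM to 1100 nM. The expected step is a 1.2-fold higher number from compound 3 to compound 4 (0.08 log units; within the scatter).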

Compound 4, half-maximal inhibitory concentration: 340 nM
Beside the measured number, compound 4's estimate is 1.2-fold (0.07 log units) above it; measured number inside the range.
By their numbers in this assay, from the lowest: compounds 2, 3 and 4 (each within the scatter of the next); then compound 1.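

In this assay, putting the 3,4-dihydroxy-5-(hydroxymethyl)oxolan-2-yl on an aromatic nitrogen of the five-membered aromatic ring with 3 nitrogen gives a 1.0-fold higher number from compound 3 to compound 4 (0.01 log units; within the scatter) when it replaces the (2,2-dimethyl-1,3-dioxolan-4-yl)methyl, and a 1.8-fold higher number from compound 2 to compound 4 (0.25 log units; within the scatter) when it replaces the (5-(hydroxymethyl)-2,2-dimethyl-1,3-dioxolan-4-yl)methyl. The earlier step altered only part of the substituent, whereas these replace all of it: a ring with 1 hetero atom and 3 hydrogen-bond donors enters where a ring with 2 hetero atoms and 0 donors stood, and neither step leaves the scatter, so across compounds 2, 3 and 4 this position tolerates the exchange without a readable change in the number. No independent measurement bears on why these numbers stay together.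

Still open is whether a tertiary amine, a carboxylic acid or a plain longer alkyl chain on the same aromatic nitrogen would also stay within the scatter of these compounds. Also open, going by these compounds, is whether the 4 defined stereocentres of the entering group matter, since compound 4 shows a single arrangement of them.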